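From hydroxy to methoxy on compound 1

The source may report more compounds than this note shows. Statements on the series, on what has been measured and on what is new or still open speak of the compounds shown alone.

Compound 1 `O=C(NCCCNc1cc(-c2cn(-c3ccccc3)nc2-c2cccc(O)c2)ccn1)Nc1ccc(F)cc1`: 5380 nM
Compound 2 `O=C(NCCCNc1cc(-c2cn(-c3ccccc3)nc2-c2cccc(O)c2)ccn1)Nc1cccc(C(F)(F)F)c1`: 7180 nM
Compound 3 `COc1cccc(-c2nn(-c3ccccc3)cc2-c2ccnc(NCCCNC(=O)Nc3ccc(F)cc3)c2)c1`: not yet measured

In a functional assay on SF-539 cells (Homo sapiens) for antiproliferative activity, read by sulforhodamine B assay, with a stated time of 48 h (on this read-out higher numbers stand for weaker inhibition of growth and lower numbers for stronger inhibition of growth), compound 1 gives 5380 nM, a value within the scatter of compound 2. Compound 3 differs from compound 1 by methyl in place of hydrogen on an oxygen on an aromatic ring, which turns 3-hydroxyphenyl into 3-methoxyphenyl. Among the measured compounds shown here, the only measured step, a 1.3-fold higher number from compound 1 to compound 2 (0.13 log units; within the scatter), concerns an amide-type nitrogen rather than this oxygen, so it bears only indirectly and no measured step tests the new change. A shift beyond the scatter is therefore not expected, and the expected step is a 1.3-fold higher number from compound 1 to compound 3 (0.11 log units; within the scatter). For compound 3 the estimated value is 7000 nM, expected to fall between 3000 nM and 16000 nM.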

Compound 3, concentration for total growth inhibition: 13400 nM
Compound 3: middle estimate off by 1.9-fold (0.28 log units), on the low side, within the range that was stated.
By their numbers in this assay, from the lowest: compounds 1, 2 and 3 (each within the scatter of the next, the first and the last beyond it).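

Methyl in place of hydrogen on the oxygen on the aromatic ring gives a 2.5-fold higher number from compound 1 to compound 3 (0.40 log units; beyond the scatter) in this assay and so shows that this position responds to substitution, with methoxy giving weaker inhibition of growth than hydroxy. The earlier step, at the amide-type nitrogen, stayed within the scatter and said nothing about this oxygen. No evidence is available on what lies behind this shift.

From the compounds shown here alone, it remains open whether an amine or an ethoxy group in place of the hydroxy would behave like methoxy. Going by these compounds, it is also open whether the same change on compound 2 would give a similar step.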